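Compound 2: isoquinolin-3-yl to 1H-benzimidazol-2-yl

The source may hold more compounds than are shown below. What is called first, only, known or untested is meant among the compounds shown, and "the series" means these compounds.

Measured in an ADME assay on microsomes from liver (Mus musculus) for metabolic stability, read by LC-MS, with a stated time of 10 min, tested at 0.5 uM (a lower number here means that less of the compound is left, a higher number that more of the compound is left), so far
- compound 1 `c1ccc2c(c1)CN[C@@H](CN(CC[C@@H]1CCCNC1)[C@H]1CCCc3cccnc31)C2` gives 23%
- compound 2 `c1cnc2c(c1)CCC[C@@H]2N(CCCN1CCNCC1)Cc1cc2ccccc2cn1` gives 74%

Compound 2 stands highest of the two in this assay with 74% and lies beyond the scatter from compound 1. Compound 3 `c1cnc2c(c1)CCC[C@@H]2N(CCCN1CCNCC1)Cc1nc2ccccc2[nH]1` has 1H-benzimidazol-2-yl in place of isoquinolin-3-yl on a saturated chain carbon bound to an amine nitrogen. Among the compounds with values here, no measured pair isolates this change, so the expectation is loose. A small fall that stays within the scatter is expected, estimated as a number 8 percentage points lower from compound 2 to compound 3 (within the scatter) in this assay for this step. Compound 3 is expected at 66% (from 40% to 88%).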

Compound 3, percent of the compound remaining: 68%
Compound 3: the middle estimate sits 2 percentage points below what was measured; the measured number falls inside the stated range.
By their numbers in this assay, from the lowest: compound 1; then compounds 3 and 2 (each within the scatter of the next).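

In this assay the exchange at this place, on a saturated chain carbon bound to an amine nitrogen, gives a number 6 percentage points lower from compound 2 to compound 3 (within the scatter). Within the data shown here, this is the first single-place step here, and it shows that a five-membered aromatic ring with 2 hetero atoms and 1 hydrogen-bond donor can replace isoquinolin-3-yl with no step beyond the scatter. Nothing measured here explains this result. The compounds shown leave open whether the hydrogen on the ring nitrogen matters, as 1-methyl-1H-benzimidazol-2-yl would show. They also leave open how a single ring such as pyridin-2-yl would read at this place.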